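Shortening the Ether Chain on the Saturated Ring Carbon

The source may hold more compounds than are shown below. What is called first, only, known or untested is meant among the compounds shown, and "the series" means these compounds.

Compound 1 `Cc1nn(-c2ncnc3nc[nH]c23)c2c1C(c1ccc(OC(C)C)cc1)CC(=O)N2` gives 2700 nM in a functional assay on HEK293 cells for agonist activity at G-protein coupled receptor 39 (Homo sapiens), read by scintillation proximity assay and inositol phosphate accumulation, with a stated time of 75 min; a higher number here means that more compound is needed for the effect, a lower number that less compound is needed.
Compound 2 `Cc1nn(-c2ncnc3nc[nH]c23)c2c1C(NC(=O)c1ccccc1)CC(=O)N2` gives 158 nM in this assay.
Compound 3 `Cc1nn(-c2ncnc3nc[nH]c23)c2c1C(OCCn1cccn1)CC(=O)N2` gives 2270 nM in this assay.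

Compound 3 stands second highest of the three numbers in this assay: compound 1 is its nearest neighbour, with a difference that stays within the scatter, and compound 2 is furthest away, the gap being large. Compound 4 `Cc1nn(-c2ncnc3nc[nH]c23)c2c1C(OCC(C)C)CC(=O)N2` keeps the shared core and the oxygen on the saturated ring carbon; the change is isopropyl in place of (1H-pyrazol-1-yl)methyl on a saturated chain carbon bound to an oxygen on a saturated carbon.

Going by the values given here, none of the measured steps alters the ether chain itself. The large steps, a 17-fold lower number from compound 1 to compound 2 (1.23 log units; beyond the scatter) and a 14-fold higher number from compound 2 to compound 3 (1.16 log units; beyond the scatter), concern the benzamido group, which compound 4 does not carry. The step of a 1.2-fold lower number from compound 1 to compound 3 (0.08 log units; within the scatter) shows that a 4-isopropoxyphenyl group and a 2-(1H-pyrazol-1-yl)ethoxy group land within the scatter of each other, so the three compounds without benzamido differ little in this assay. He therefore expects no step beyond the scatter for compound 4, in either direction, as a 1.3-fold higher number from compound 3 to compound 4 (0.12 log units; within the scatter). His estimate for compound 4 in this assay is 3000 nM, between 1000 nM and 9000 nM.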

Compound 4, half-maximal effective concentration: 111 nM
For compound 4 the middle estimate is 27-fold (1.43 log units) above the measured one; measured number below the stated range.
By their numbers in this assay, from the lowest: compounds 4 and 2 (each within the scatter of the next); then compounds 3 and 1 (each within the scatter of the next).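

Isopropyl in place of (1H-pyrazol-1-yl)methyl gives a 20-fold lower number from compound 3 to compound 4 (1.31 log units; beyond the scatter) in this assay, the first sign that the end of the ether chain counts here and that the oxygen on the saturated ring carbon does not settle the number alone. Isobutoxy in place of 4-isopropoxyphenyl gives a 24-fold lower number from compound 1 to compound 4 (1.39 log units; beyond the scatter) and isobutoxy in place of benzamido gives a 1.4-fold lower number from compound 2 to compound 4 (0.15 log units; within the scatter), so among these compounds benzamido is not the only group on the saturated ring carbon that reaches the low end, although compound 3 shows that not every ether does so. Nothing available explains why the two ether chains part so far.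

On these data alone, it remains open whether the isobutyl group itself matters or only the loss of the pyrazole ring, which a longer chain such as n-pentyl or a chain ending in an amine would help to separate. As far as these compounds go, whether the oxygen matters also stays open, and an isobutylamino group on the saturated ring carbon would be the direct comparison.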